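Styryl in place of chlorophenyl on the saturated ring carbon

A few compounds are considered here, and "the series" means these few. Any claim that something is new, unique, unknown or untested is made for them only; others in the source may bear on it.

For the measured compounds named here, compound 2 `NS(=O)(=O)c1ccc(N2N=C(c3cccc(O)c3)C[C@H]2c2ccc(Cl)cc2)cc1` gives the lowest number of the three measured members. In a functional assay on the whole organism (strain Wistar albino) for inhibition, with Rattus norvegicus as the target, read by paw edema, with stated times of 30 min and 3 h, at a dose of 0.05 mmol/kg (a higher number here means more inhibition at the dose given (going by the name of the read-out), a lower number less inhibition), compound 2 gives 19.2%. Its nearest neighbour is compound 1 `NS(=O)(=O)c1ccc(N2N=C(c3cccc(O)c3)C[C@H]2c2ccccc2)cc1`, which in this assay gives 35.8%; furthest off is compound 3 `COc1ccc([C@@H]2CC(c3cccc(O)c3)=NN2c2ccc(S(N)(=O)=O)cc2)cc1OC`, which in this assay gives 55.9%. Both measured steps out of compound 2 go upward: a number 16.6 percentage points lower from compound 1 to compound 2 (beyond the scatter) read backward, and a number 36.7 percentage points higher from compound 2 to compound 3 (beyond the scatter). The third measured step, a number 20.1 percentage points higher from compound 1 to compound 3 (beyond the scatter), shows the same direction for the dimethoxy group.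

Compound 4 `NS(=O)(=O)c1ccc(N2N=C(c3cccc(O)c3)C[C@H]2/C=C/c2ccccc2)cc1` has not yet been tested. It differs from compound 2 as follows: 2-phenylethenyl in place of 4-chlorophenyl on a saturated ring carbon

Going by the values given here, no measured step places an alkenyl group on the saturated ring carbon, so the size of the change is not read directly. The step from compound 1 to compound 2 shows that the chloro substituent carried a modest loss, and compound 4 drops that chloro; the entering group otherwise keeps a single carbon-only aromatic ring, as in compound 1. A modest rise is therefore expected in this assay, toward the value of compound 1 rather than toward that of compound 3. Compound 4 is estimated at 33%, with a range from 18% to 50%, meaning an expected step of a number 13.8 percentage points higher from compound 2 to compound 4 (beyond the scatter).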

Compound 4, a percentage reported as inhibition, in the whole organism at one dose (the size of the read-out at that dose, not a potency): 39.9%
Beside the measured number, compound 4's estimate is 6.9 percentage points below it; the measured number falls inside the stated range.
By their numbers in this assay, from the lowest: compound 2; then compounds 1 and 4 (each within the scatter of the next); then compound 3.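

At the saturated ring carbon, 2-phenylethenyl in place of phenyl gives a number 4.1 percentage points higher from compound 1 to compound 4 (within the scatter), so in this assay these two carbon-only groups cannot be told apart, even though the entering group brings a double bond outside the aromatic ring. The same entering group gives a number 20.7 percentage points higher from compound 2 to compound 4 (beyond the scatter) when it takes the place of 4-chlorophenyl and a number 16 percentage points lower from compound 3 to compound 4 (beyond the scatter) when it takes the place of 3,4-dimethoxyphenyl, so compounds 1 and 4 together lie clear of both substituted members, above compound 2 and below compound 3. Nothing on hand explains these differences at this position.

From the compounds shown here alone, it remains open whether substituents on the ring of the 2-phenylethenyl group would shift the number in the same directions as chloro and the two methoxy groups do on the directly attached phenyl ring. Also open, going by these compounds, is how the series would read with a 2-phenylethyl group, which lacks the double bond, or with a simple amine such as piperidine on the same saturated ring carbon.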